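Swapping Chloro for Trifluoromethyl on the Amide Aryl

The compounds below may be only part of what the source reports. "The series", "measured", "known", "first", "only" and "open" are said of these compounds alone.

Three compounds share one core and differ only in the aryl group on the amide nitrogen. In a functional assay on MDA-MB-231 cells (Homo sapiens) for inhibition, read by MTT assay, with a stated time of 72 h (a higher number here means a weaker inhibitor, a lower number a stronger inhibitor), compound 1 `O=C(CSc1nc(Nc2ccccc2)c2ccccc2n1)Nc1cccc([N+](=O)[O-])c1` gives 33000 nM, compound 2 `CCc1cccc(NC(=O)CSc2nc(Nc3ccccc3)c3ccccc3n2)c1` gives 12400 nM, and compound 3 `O=C(CSc1nc(Nc2ccccc2)c2ccccc2n1)Nc1ccc(Cl)cc1` gives 17200 nM. Compound 3 thus sits second highest of the three numbers, with both neighbours close: a 1.9-fold lower number from compound 1 to compound 3 (0.28 log units; within the scatter) and a 1.4-fold higher number from compound 2 to compound 3 (0.14 log units; within the scatter). Compound 4 `O=C(CSc1nc(Nc2ccccc2)c2ccccc2n1)Nc1ccc(C(F)(F)F)cc1` carries trifluoromethyl in place of chloro on an aromatic carbon. Within the data shown here, no measured step swaps these two groups, and the two steps that change this same aryl group both stay within the scatter, so no step beyond the scatter is expected. Compound 4 is therefore expected to give 15000 nM in this assay, between 6000 nM and 40000 nM, meaning an expected step of a 1.1-fold lower number from compound 3 to compound 4 (0.06 log units; within the scatter).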

Compound 4, half-maximal inhibitory concentration: 11100 nM
The estimate for compound 4 lay 1.4-fold (0.13 log units) above the measured number; the range from low to high includes it.
By their numbers in this assay, from the lowest: compounds 4, 2, 3 and 1 (each within the scatter of the next, the first and the last beyond it).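

Trifluoromethyl, with 4 heavy atoms, can take the place of chloro, with 1, on this aromatic carbon para to a large group, and in this assay the size of the group leaves no clear mark: a 1.5-fold lower number from compound 3 to compound 4 (0.19 log units; within the scatter). Compound 4 also stays level with the 3-ethylphenyl compound, a 1.1-fold lower number from compound 2 to compound 4 (0.05 log units; within the scatter), while a 3.0-fold lower number from compound 1 to compound 4 (0.47 log units; beyond the scatter) is, after the step to compound 2, a second step away from the 3-nitrophenyl compound that passes beyond the scatter. Nothing available explains these numbers. Going by these compounds, how an amine, a carboxylic acid or a longer chain on this aryl group would read remains open.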